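Chloro for nitro on the sulfonyl aryl of compound 2

This account rests on a few compounds, and the source may have more. Where it says the series, first, only, none or still open, it means among the compounds named here.

Among the measured compounds shown here, compound 2 `COc1ccc(-c2cc(=O)c3c(OC)cc(OC)cc3n2S(=O)(=O)c2ccc([N+](=O)[O-])cc2)cc1` gives 17300 nM in a functional assay on KOPN-8 cells (Homo sapiens) for antiproliferative activity, with a stated time of 72 h (a lower number here means that less compound is needed, a higher number that more compound is needed for the effect), the highest of the two numbers so far; compound 1 `COC(=O)c1cc(=O)c2c(OC)cc(OC)cc2n1S(=O)(=O)c1ccc(C)cc1` gives 6000 nM in this assay, a gap that lies beyond the scatter. Compound 3 `COc1ccc(-c2cc(=O)c3c(OC)cc(OC)cc3n2S(=O)(=O)c2ccc(Cl)cc2)cc1` differs from compound 2 by chloro in place of nitro on an aromatic carbon. For the measured compounds named here, no measured pair shows this exchange, so the direction is open; the step is expected to be a 1.2-fold lower number from compound 2 to compound 3 (0.06 log units; within the scatter), not beyond the scatter. Compound 3 is therefore estimated at 15000 nM in this assay, between 6000 nM and 40000 nM.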

Compound 3, half-maximal effective concentration: > 34400 nM
Compound 3 gave a limit, no number; the forecaster's own chance of this, stated with the estimate: 15%; middle value at least 2.2-fold (0.36 log units) away from the limit.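

Compound 3 gives a limit in this assay, not a number: the limit of > 34400 nM in this assay, at which 1 of the 3 values shown sits.

Among the compounds shown here, the exchange of 4-nitrophenyl for 4-chlorophenyl is the first measured change at this position, with an at least 1.9-fold higher number from compound 2 to compound 3 (0.29 log units; that floor lies within the scatter). Chloro therefore gives no sign of a lower number than nitro here, though the floor of this step does not clear the scatter.

From the compounds shown here alone, the true size of the step stays open, as the limit gives only its floor. Also open, going by these compounds, is whether an amine or a carboxylic acid on this aromatic carbon would lower the number.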